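The source may hold more compounds than are shown below. What is called first, only, known or untested is meant among the compounds shown, and "the series" means these compounds.

Measured compounds:
- Compound 1, `CCn1c(C(=O)NCC#N)ccc1C(CC)(CC)c1ccc(OCCC(O)(CC)CC)c(C)c1`: in a functional assay on PC-3 cells (Homo sapiens) for antiproliferative activity, read by MTT assay, with a stated time of 48 h (on this read-out lower numbers stand for stronger inhibition and higher numbers for weaker inhibition), compound 1 gives 17800 nM.
- Compound 2, `CCn1c(C(=O)Nc2cccc(C(F)(F)F)c2)ccc1C(CC)(CC)c1ccc(OCCC(O)(CC)CC)c(C)c1`: in this assay compound 2 gives 23800 nM.

Both numbers sit at the weak end of the range that can be read in this assay. Among the compounds with values here, compound 2 has the highest of the two numbers, but its only neighbour is compound 1, and the single step that connects them, a 1.3-fold higher number from compound 1 to compound 2 (0.13 log units; within the scatter), changes nothing that the scatter would not cover. No ordering between compound 2 and compound 1 can be read from these two values.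

Compound 3, `CCC(C)C(CO)NC(=O)c1ccc(C(CC)(CC)c2ccc(OCCC(O)(CC)CC)c(C)c2)n1CC`, has not yet been measured. It differs from compound 2 as follows: 1-(hydroxymethyl)-2-methylbutyl in place of 3-(trifluoromethyl)phenyl on an amide-type nitrogen. Within the data shown here, the only step available on this amide-type nitrogen is the one from compound 1 to compound 2, and that step stayed within the scatter. Among the measured compounds shown here, a group that carries a hydrogen-bond donor and acceptor and no ring has no counterpart among the measured compounds, so nothing indicates a shift in either direction. The expected step is therefore a 1.2-fold lower number from compound 2 to compound 3 (0.08 log units; within the scatter), no more than the scatter. For compound 3 the estimate in this assay is 20000 nM, with a range from 7000 nM to 60000 nM.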

Compound 3, half-maximal inhibitory concentration: 28400 nM
Beside the measured number, compound 3's estimate is 1.4-fold (0.15 log units) below it; the range from low to high includes it.
By their numbers in this assay, from the lowest: compounds 1, 2 and 3 (each within the scatter of the next).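

In this assay, the amide-type nitrogen now carries three different groups, and the series gains its first member with no ring on the amide side chain beyond cyanomethyl, plus a hydrogen-bond donor and acceptor in 1-(hydroxymethyl)-2-methylbutyl. Exchanging 3-(trifluoromethyl)phenyl for this group gives no readable difference (a 1.2-fold higher number from compound 2 to compound 3 (0.08 log units; within the scatter)), and neither does exchanging cyanomethyl for it (a 1.6-fold higher number from compound 1 to compound 3 (0.20 log units; within the scatter)), so a large aromatic group, a small nitrile-bearing group and a branched hydroxymethyl-bearing chain cannot be told apart at this position in this read-out. Nothing shown bears on why these groups are indistinguishable here.

All three compounds shown share the same core, so it stays open whether any group on this nitrogen can separate itself from the scatter, for example a chain ending in a primary amine, a carboxylic acid, or a plain amide hydrogen with no substituent at all. From the compounds shown here alone, it also stays open whether the numbers in this assay depend on the rest of the shared core rather than on this amide-type nitrogen.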